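Swapping the N-oxy chain of compound 2 for a nitrophenyl ring

A few compounds are considered here, and "the series" means these few. Any claim that something is new, unique, unknown or untested is made for them only; others in the source may bear on it.

Of the compounds shown here, two have been measured in an assay on HEK293 cells for inhibition of N-acylethanolamine-hydrolyzing acid amidase (Homo sapiens), read by fluorescence, with stated times of 10 min and 50 min; on this read-out lower numbers stand for stronger inhibition and higher numbers for weaker inhibition. Compound 1 `CCCCCCCON1C(=O)[C@@H](NC(=O)OCCCCC2CCCCC2)[C@@H]1C` gives 2230 nM, and compound 2 `CSCCCON1C(=O)[C@@H](NC(=O)OCCCCC2CCCCC2)[C@@H]1C` gives 167 nM. Within the data shown here, the single step between them, a 13-fold lower number from compound 1 to compound 2 (1.13 log units; beyond the scatter), is the only step available, so compound 2 has the lowest number of the two. Compound 3 `C[C@H]1[C@H](NC(=O)OCCCCC2CCCCC2)C(=O)N1Oc1ccc([N+](=O)[O-])cc1` is the unmeasured member of the series; it differs from compound 2 by 4-nitrophenyl in place of 3-(methylsulfanyl)propyl on an oxygen. Among the measured compounds shown here, the one measured step concerns a change on the same oxygen but alters only the chain, so it bears on the move to compound 3 only loosely and offers no direct precedent for placing a ring there. With nothing beyond that to go on, the author expects compound 3 to land near compound 2, with the step of a 1.4-fold lower number from compound 2 to compound 3 (0.14 log units; within the scatter) treated as uncertain in either direction. The estimate for compound 3 is 120 nM, within 20 nM to 800 nM.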

Compound 3, half-maximal inhibitory concentration: 17 nM
Estimate against measurement, compound 3: 7.1-fold (0.85 log units) above, and the stated range ends above it.
By their numbers in this assay, from the lowest: compound 3; then compound 2; then compound 1.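

In this assay, among these compounds, the earlier compounds had only saturated chains on the oxygen attached to the amide-type nitrogen in a ring, and they did not show how an aromatic ring would behave there. Placing 4-nitrophenyl on that oxygen gives a 9.8-fold lower number from compound 2 to compound 3 (0.99 log units; beyond the scatter), so the change goes beyond replacing one chain with another. Against the heptyl chain the difference is wider, with a 130-fold lower number from compound 1 to compound 3 (2.12 log units; beyond the scatter), which makes compound 3 the strongest inhibitor of the three in this assay.

Nothing available explains why the number falls with this change. Going by these compounds, it remains open whether the benzene ring alone or its nitro group accounts for the drop, a question that a plain phenyl ring, or a phenyl ring bearing a nitrile or an amine instead of the nitro group, could address.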